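The source may report more compounds than this note shows. Statements on the series, on what has been measured and on what is new or still open speak of the compounds shown alone.

Measured so far:
compound 1 `Cc1cn(-c2cc(NC(=O)c3ccc(C)c(Oc4ccccc4)c3)cc(N3CCN(C)CC3)c2)cn1` — 7.36 h
compound 2 `Cc1cn(-c2cc(NC(=O)c3ccc(C)c(Oc4cccc5ccncc45)c3)cc(N3CCN(C)CC3)c2)cn1` — 2.77 h

In an ADME assay on the whole organism (Mus musculus, strain CD1) for metabolic stability, read by LC-MS, using cassette dosing, with a stated time of 24 h, at a dose of 0.4 mg/kg by the intravenous route (on this read-out higher numbers stand for a longer-lived compound and lower numbers for a shorter-lived compound), compound 2 gives 2.77 h, the lowest of the two numbers measured; compound 1 gives 7.36 h, and the step of a 2.7-fold lower number from compound 1 to compound 2 (0.42 log units; beyond the scatter) places isoquinolin-8-yl in place of phenyl on an oxygen on an aromatic ring. Compound 3 `Cc1cn(-c2cc(NC(=O)c3ccc(C)c(C(=O)c4cccc(C#N)c4)c3)cc(N3CCN(C)CC3)c2)cn1` differs from compound 2 by (3-cyanophenyl)carbonyl in place of (isoquinolin-8-yl)oxy on an aromatic carbon, on an aromatic carbon of a six-membered aromatic ring of carbon only, ortho to a methyl group and meta to a large group. Among the compounds with values here, no measured step replaces the oxygen link itself; the only step that bears on this position is the step from compound 1 to compound 2, which changed the group on that oxygen and was modest in size. In this assay the estimate for compound 3 is therefore a step of about a 1.4-fold higher number from compound 2 to compound 3 (0.16 log units; within the scatter), with wide uncertainty in either direction. Compound 3 is estimated at 4 h, expected to fall between 1.6 h and 10 h.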

Compound 3, half-life: 1.09 h
Compound 3: the middle estimate sits 3.7-fold (0.56 log units) above what was measured, outside the stated range (below it).
By their numbers in this assay, from the lowest: compound 3; then compound 2; then compound 1.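

In this assay the position was now changed at the link as well as at the ring, and (3-cyanophenyl)carbonyl in place of (isoquinolin-8-yl)oxy gave a 2.5-fold lower number from compound 2 to compound 3 (0.41 log units; beyond the scatter). Set against phenoxy, the same group gave a 6.8-fold lower number from compound 1 to compound 3 (0.83 log units; beyond the scatter), so compound 1 holds the highest number of the three, and both departures from its phenoxy group, with the oxygen kept or replaced, lowered the half-life. No measurement at hand accounts for either drop.

Compound 3 changes the link and the ring together, so these compounds cannot say how much of its drop belongs to the carbonyl and how much to the nitrile-bearing ring. On these data alone, it also remains open how the half-life would respond to an amine link on this aromatic carbon, or to a phenyl ring carrying no nitrile on the carbonyl.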